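From Nitro to Methoxy in Compound 3

A few compounds are considered here, and "the series" means these few. Any claim that something is new, unique, unknown or untested is made for them only; others in the source may bear on it.

In a functional assay on MGC-803 cells (Homo sapiens) for antiproliferative activity, read by MTT assay, with a stated time of 48 h (on this read-out higher numbers stand for weaker inhibition and lower numbers for stronger inhibition), compound 3 `COc1ccc(CN(C(=O)CSc2nc3ccccc3s2)c2cc(OC)c(OC)c(OC)c2)cc1[N+](=O)[O-]` gives 682 nM, the highest number among the three measured compounds. Compound 1 `COc1ccc(CN(C(=O)CSc2nc3ccccc3s2)c2cc(OC)c(OC)c(OC)c2)cc1N=[N+]=[N-]` gives 187 nM and compound 2 `COc1ccc(CN(C(=O)CSc2nc3ccccc3s2)c2cc(OC)c(OC)c(OC)c2)cc1` gives 163 nM. Azido and hydrogen at this place hardly separate, with a 1.1-fold lower number from compound 1 to compound 2 (0.06 log units; within the scatter).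

Compound 4 `COc1ccc(CN(C(=O)CSc2nc3ccccc3s2)c2cc(OC)c(OC)c(OC)c2)cc1OC` keeps the shared core and changes one group, turning 4-methoxy-3-nitrobenzyl into 3,4-dimethoxybenzyl. This puts methoxy in place of nitro on an aromatic carbon.

Among the compounds with values here, two measured steps bear most directly on this change, since both introduce the same nitro group that now leaves. They are a 4.2-fold higher number from compound 2 to compound 3 (0.62 log units; beyond the scatter) and a 3.6-fold higher number from compound 1 to compound 3 (0.56 log units; beyond the scatter). Among these three compounds, only the one carrying nitro stands apart. Within the data shown here, no measured compound has methoxy at this place, so the size of the return in this assay is uncertain. A modest step toward a lower number is expected, probably a little smaller than those two, leaving the result somewhat above the other two values. The estimate amounts to a 2.6-fold lower number from compound 3 to compound 4 (0.42 log units; beyond the scatter). Compound 4 is therefore expected at about 260 nM, with an estimated range from 110 nM to 620 nM.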

Compound 4, half-maximal inhibitory concentration: 34100 nM
For compound 4 the middle estimate is 130-fold (2.12 log units) below the measured one; measured number outside the range, above it.
By their numbers in this assay, from the lowest: compounds 2 and 1 (each within the scatter of the next); then compound 3; then compound 4.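

In this assay, methoxy at this place does something none of the earlier groups did, and the earlier spread between nitro, azido and hydrogen now looks small beside it (a 50-fold higher number from compound 3 to compound 4 (1.70 log units; beyond the scatter)). The change is just as sharp measured against the two compounds that had been close together, with methoxy in place of hydrogen (a 210-fold higher number from compound 2 to compound 4 (2.32 log units; beyond the scatter)) and methoxy in place of azido (a 180-fold higher number from compound 1 to compound 4 (2.26 log units; beyond the scatter)), so the large rise follows the arrival of methoxy on this aromatic carbon, ortho to a methoxy group, and not the departure of nitro alone. Nothing available here explains why this one group stands so far from the other three.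

The compounds shown place only hydrogen, azido, nitro and methoxy on this carbon, so it stays open whether the sharp rise belongs to methoxy alone or extends to hydroxyl, ethoxy, a longer ether chain or an amine. Going by these compounds, it also stays open whether a smaller group such as fluorine would sit with hydrogen and azido or nearer to compound 4.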